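A few compounds are considered here, and "the series" means these few. Any claim that something is new, unique, unknown or untested is made for them only; others in the source may bear on it.

Two compounds have been measured so far in an ADME assay on the whole organism (strain FVB) for pharmacokinetics, with Mus musculus as the target, read by LC-MS, at a dose of 30 mg/kg by the oral route (on this read-out lower numbers stand for lower exposure and higher numbers for higher exposure at the dose given), and they stand as follows:

Compound 1 `CC(C)(N)CCOc1ccc([C@H]2CC[C@]3(CC2)OOC2(O3)C3CC4CC(C3)CC2C4)cc1` gives 1050 nM

Compound 2 `N[C@H]1CC[C@@H](Oc2ccc([C@H]3CC[C@]4(CC3)OOC3(O4)C4CC5CC(C4)CC3C5)cc2)CC1` gives 1170 nM

Going by the values given here, compound 2 lies within the scatter of compound 1, the only other measured compound, so the two cannot be ranked. Compound 3 `O[C@H]1CC[C@H](NCCCOc2ccc([C@H]3CC[C@]4(CC3)OOC3(O4)C4CC5CC(C4)CC3C5)cc2)CC1` differs from compound 2 by 3-((4-hydroxycyclohexyl)amino)propyl in place of 4-aminocyclohexyl on an oxygen on an aromatic ring and the group that enters keeps a six-membered non-aromatic ring of carbon only, with no net charge, like the group that leaves.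

Among the compounds with values here, only one measured step bears on this change. It is a 1.1-fold higher number from compound 1 to compound 2 (0.05 log units; within the scatter) and it too swaps one group on that oxygen for another, without leaving the scatter. Within the data shown here, that is thin evidence, and no measured compound carries the 3-((4-hydroxycyclohexyl)amino)propyl group. No step beyond the scatter is therefore expected in this assay although a modestly lower number would not surprise, and the direction remains uncertain. The expected step is a 1.4-fold lower number from compound 2 to compound 3 (0.14 log units; within the scatter) and so stays within the scatter. Compound 3 is expected at 850 nM with an estimated range of 300 nM to 2200 nM for four of five measurements.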

Compound 3, maximal plasma concentration: 721 nM
Compound 3: the middle estimate sits 1.2-fold (0.07 log units) above what was measured; the measured number falls inside the stated range.
By their numbers in this assay, from the lowest: compounds 3, 1 and 2 (each within the scatter of the next).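

The third group on this oxygen on an aromatic ring extends the range of groups seen at this position: in this assay the step is a 1.6-fold lower number from compound 2 to compound 3 (0.21 log units; within the scatter), so 3-((4-hydroxycyclohexyl)amino)propyl, with 11 heavy atoms and 2 hydrogen-bond donors, stays within the scatter of 4-aminocyclohexyl, with 7 heavy atoms and 1 hydrogen-bond donor. The comparison with the 3-amino-3-methylbutyl group reads the same, at a 1.5-fold lower number from compound 1 to compound 3 (0.16 log units; within the scatter), so at this dose the read-out cannot rank these three quite different groups, and a larger group carrying both a ring and a hydroxyl has not moved it beyond the scatter. Nothing at hand explains why these numbers lie so close together.

From the compounds shown here alone, the separate contribution of the hydroxyl in the entering group remains open, and a plain cyclohexyl on the same propyl amine would be the direct comparison. Also open, going by these compounds, is whether a different kind of group on this oxygen, such as a carboxylic acid or a morpholine at the end of the propyl chain, would move the maximal plasma concentration beyond the scatter.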